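Series notes: aryl substituent on the triazole nitrogen

This account rests on a few compounds, and the source may have more. Where it says the series, first, only, none or still open, it means among the compounds named here.

Among the compounds with values here, compound 2 `COc1ccc(/C=C\C(=O)O)c(OCc2cn(-c3ccccc3C#N)nn2)c1CC=C(C)C` gives 8800 nM in a functional assay on T47D cells (Homo sapiens) for cytotoxicity, read by MTT assay, with a stated time of 24 h (a higher number here means a weaker inhibitor, a lower number a stronger inhibitor), the lowest of the two numbers measured so far; compound 1 `COc1ccc(/C=C\C(=O)O)c(OCc2cn(-c3ccccc3)nn2)c1CC=C(C)C` gives 34100 nM in this assay. Within the data shown here, the one measured step, a 3.9-fold lower number from compound 1 to compound 2 (0.59 log units; beyond the scatter), concerns the same aryl substituent. Compound 3 `COc1ccc(/C=C\C(=O)O)c(OCc2cn(-c3ccc(NC(C)=O)cc3)nn2)c1CC=C(C)C` differs from compound 2 by 4-acetamidophenyl in place of 2-cyanophenyl on an aromatic nitrogen. The cyano that entered in that measured step leaves here, and nothing measured speaks to the acetamido group. A modest upward step in this assay is therefore expected, a 1.8-fold higher number from compound 2 to compound 3 (0.26 log units; within the scatter). Compound 3 is estimated at 16000 nM, with a range from 5000 nM to 50000 nM.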

Compound 3, half-maximal inhibitory concentration: 17400 nM
Compound 3: the middle estimate sits 1.1-fold (0.04 log units) below what was measured, within the range that was stated.
By their numbers in this assay, from the lowest: compounds 2, 3 and 1 (each within the scatter of the next, the first and the last beyond it).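

In this assay, the 4-acetamidophenyl group on the aromatic nitrogen gives no readable separation from either neighbour: a 2.0-fold higher number from compound 2 to compound 3 (0.30 log units; within the scatter) and a 2.0-fold lower number from compound 1 to compound 3 (0.29 log units; within the scatter) both lie within the scatter. Among the three compounds, only a 3.9-fold lower number from compound 1 to compound 2 (0.59 log units; beyond the scatter) remains a readable difference at this position. An acetamido group here therefore gives no reading apart from the unsubstituted phenyl.

On these data alone, whether a 4-cyanophenyl group or an amine on the same phenyl would read apart from compound 1 remains open. No supporting evidence bears on these numbers.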